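Swapping the amide aryl group in a flavonol series

The source may report more compounds than this note shows. Statements on the series, on what has been measured and on what is new or still open speak of the compounds shown alone.

Compound 2 `COc1ccccc1C(=O)Nc1cccc(-c2oc3cc(-c4ccc(F)cc4)ccc3c(=O)c2O)c1` and compound 1 `O=C(Nc1cccc(-c2oc3cc(-c4ccc(F)cc4)ccc3c(=O)c2O)c1)c1ccc(F)cc1` share one core and differ only in the aromatic ring attached to the carbonyl carbon of the amide. In a functional assay on HepG2 cells (Homo sapiens) for antiproliferative activity, read by CCK-8 assay, with a stated time of 72 h (on this read-out higher numbers stand for weaker inhibition and lower numbers for stronger inhibition), compound 1 gives 9280 nM, and compound 2 gives 14500 nM. Of these two numbers compound 2 has the higher one, yet the step of a 1.6-fold higher number from compound 1 to compound 2 (0.19 log units; within the scatter) stays within the scatter, so the two compounds cannot be told apart on this read-out.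

Compound 3 `Cc1cccc(C(=O)Nc2cccc(-c3oc4cc(-c5ccc(F)cc5)ccc4c(=O)c3O)c2)c1` takes the same approach one step further: 3-methylphenyl in place of 2-methoxyphenyl on a carbonyl carbon. For the measured compounds named here, the only measured step that speaks to this kind of change is the one from compound 1 to compound 2, which exchanged one aromatic ring on the carbonyl carbon for another and produced no movement beyond the scatter. On that basis the expectation for compound 3 is a step of a 1.2-fold lower number from compound 2 to compound 3 (0.08 log units; within the scatter) of no real size in either direction. Compound 3 is therefore estimated at 12000 nM, with a likely range from 5000 nM to 30000 nM.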

Compound 3, half-maximal inhibitory concentration: 13500 nM
Beside the measured number, compound 3's estimate is 1.1-fold (0.05 log units) below it, and the stated range covers the measured number.
By their numbers in this assay, from the lowest: compounds 1, 3 and 2 (each within the scatter of the next).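

In this assay there is a 1.1-fold lower number from compound 2 to compound 3 (0.03 log units; within the scatter) when 3-methylphenyl replaces 2-methoxyphenyl on the carbonyl carbon, and there is a 1.5-fold higher number from compound 1 to compound 3 (0.16 log units; within the scatter) when it replaces 4-fluorophenyl, so all three compounds lie within the scatter of one another. The new information is that this position has now carried three differently substituted phenyl rings, including a swap that takes away the oxygen of the methoxy group and its one hydrogen-bond acceptor, without any step that this read-out can distinguish from repeat-to-repeat noise. No measurement offered here gives any reason for this sameness.

From the compounds shown here alone, all three groups are phenyl rings with one small substituent, so it remains unknown whether the numbers would hold with a ring carrying an amine or a carboxylic acid, or with a plain alkyl chain on the carbonyl carbon in place of the ring. Since the numbers sit so close together, these compounds also cannot show whether any group at this position can move antiproliferative activity beyond the scatter in either direction.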